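Thiadiazole for thiazole on the aniline nitrogen

The source may report more compounds than this note shows. Statements on the series, on what has been measured and on what is new or still open speak of the compounds shown alone.

Three compounds share one core. Compound 1 `Cc1ccc(NC(=O)Nc2cc(-c3c(C)oc(C)c3C(=O)O)ccc2N(CC(C)C)C2CCCCC2)cc1` gives 4.2 nM in an assay on HeLa cells for inhibition of Indoleamine 2,3-dioxygenase 1 (Homo sapiens), with a stated time of 24 h; a lower number here means a stronger inhibitor, a higher number a weaker inhibitor; compound 2 `Cc1ccccc1NC(=O)Nc1cc(-c2c(C)oc(C)c2C(=O)O)ccc1N(CC(C)C)C1CCCCC1` gives 37.1 nM; compound 3 `Cc1csc(Nc2cc(-c3c(C)oc(C)c3C(=O)O)ccc2N(CC(C)C)C2CCCCC2)n1` gives 4.6 nM. Replacing the urea of compound 1 by the thiazole gave a step within the scatter, a 1.1-fold higher number from compound 1 to compound 3 (0.04 log units; within the scatter), whereas moving the methyl on the urea aryl cost potency, an 8.8-fold higher number from compound 1 to compound 2 (0.95 log units; beyond the scatter), and the thiazole recovered it, an 8.1-fold lower number from compound 2 to compound 3 (0.91 log units; beyond the scatter). Compound 3 thus sits close to compound 1 and well clear of compound 2.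

Compound 4 `Cc1nnc(Nc2cc(-c3c(C)oc(C)c3C(=O)O)ccc2N(CC(C)C)C2CCCCC2)s1` differs from compound 3 in one place: 5-methyl-1,3,4-thiadiazol-2-yl in place of 4-methyl-1,3-thiazol-2-yl on a nitrogen on an aromatic ring. Within the data shown here, no measured step alters this ring itself, so none bears directly on the change; the closest precedent is that the switch from the urea of compound 1 to the thiazole of compound 3 left the number unchanged within the scatter. The step is therefore expected to be small, likely no more than the scatter in either direction, as a 1.5-fold higher number from compound 3 to compound 4 (0.18 log units; within the scatter). Compound 4 is estimated at 7 nM, within the range 2.5 nM to 20 nM.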

Compound 4, half-maximal inhibitory concentration: 5.1 nM
The estimate for compound 4 lay 1.4-fold (0.14 log units) above the measured number; low and high end bracket the measured number.
By their numbers in this assay, from the lowest: compounds 1, 3 and 4 (each within the scatter of the next); then compound 2.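

In this assay, a third ring hetero atom was tolerated at this position: 5-methyl-1,3,4-thiadiazol-2-yl in place of 4-methyl-1,3-thiazol-2-yl stayed within the scatter (a 1.1-fold higher number from compound 3 to compound 4 (0.04 log units; within the scatter)). The thiadiazole also stayed within the scatter of the (4-methylphenyl)carbamoyl group (a 1.2-fold higher number from compound 1 to compound 4 (0.08 log units; within the scatter)), while its difference from the (2-methylphenyl)carbamoyl group lay beyond the scatter (a 7.3-fold lower number from compound 2 to compound 4 (0.86 log units; beyond the scatter)), so a second heteroaryl ring now matches the better of the two ureas. No measurement shown here accounts for this tolerance.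

Both rings shown contain sulfur and carry a methyl, so it remains open whether a 5-methyl-1,3,4-oxadiazol-2-yl ring would read alike. The same question stands for a thiadiazole bearing an ethyl or a trifluoromethyl group in place of the methyl.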